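Half-life notes: sulfonylamino in place of triazolylmethyl substituent

This account rests on a few compounds, and the source may have more. Where it says the series, first, only, none or still open, it means among the compounds named here.

Of the compounds shown here, three have been measured in an ADME assay on microsomes from liver (Homo sapiens) for metabolic stability, read by LC-MS, using NADPH, tested at 5 uM; on this read-out higher numbers stand for a longer-lived compound and lower numbers for a shorter-lived compound. Compound 1 `CN1CCN(Cc2nnc(-c3cc(S(N)(=O)=O)c(SCc4ccccc4)cc3Cl)o2)CC1` gives 0.308 h; compound 2 `NC(=O)c1cn(Cc2nnc(-c3cc(S(N)(=O)=O)c(SCc4ccccc4)cc3Cl)o2)nn1` gives 0.435 h; compound 3 `CC(C)(O)c1cn(Cc2nnc(-c3cc(S(N)(=O)=O)c(SCc4ccccc4)cc3Cl)o2)nn1` gives 0.23 h. Compound 3 holds the smallest of the three numbers, but the gaps to its neighbours are modest: a 1.3-fold lower number from compound 1 to compound 3 (0.13 log units; within the scatter) and a 1.9-fold lower number from compound 2 to compound 3 (0.28 log units; within the scatter), both within the scatter, so the three compounds are not told apart in this assay.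

Compound 4 `NS(=O)(=O)c1cc(-c2nnc(CNS(=O)(=O)c3ccc(Cl)cc3)o2)c(Cl)cc1SCc1ccccc1` is not yet measured. It differs from compound 3 in one place: ((4-chlorophenyl)sulfonyl)amino in place of 4-(1-hydroxy-1-methylethyl)-1H-1,2,3-triazol-1-yl on a saturated chain carbon bound to an aromatic carbon.

Among the compounds with values here, two measured steps touch the same saturated chain carbon, a 1.4-fold higher number from compound 1 to compound 2 (0.15 log units; within the scatter) and a 1.3-fold lower number from compound 1 to compound 3 (0.13 log units; within the scatter), and a third alters the substituent on the triazole, a 1.9-fold lower number from compound 2 to compound 3 (0.28 log units; within the scatter); every one of them stays within the scatter. None of them introduces a sulfonylamino group or a chlorophenyl ring, so the change to compound 4 is not directly covered. Within the data shown here, the only guidance is that exchanges at this position have so far left this assay unmoved, and the expectation for compound 4 is therefore a step of a 1.3-fold higher number from compound 3 to compound 4 (0.12 log units; within the scatter), that is, no change beyond the scatter, with a wide band to reflect the untested group. Compound 4 is estimated at 0.3 h, expected to fall between 0.12 h and 0.75 h.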

Compound 4, half-life: 0.197 h
Estimate against measurement, compound 4: 1.5-fold (0.18 log units) above, and the stated range covers the measured number.
By their numbers in this assay, from the lowest: compounds 4, 3, 1 and 2 (each within the scatter of the next, the first and the last beyond it).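

In this assay, ((4-chlorophenyl)sulfonyl)amino on the saturated chain carbon bound to an aromatic carbon brings a group with a six-membered aromatic ring of carbon only and no triazole or piperazine, and against two of the earlier groups it still does not separate: a 1.2-fold lower number from compound 3 to compound 4 (0.07 log units; within the scatter) and a 1.6-fold lower number from compound 1 to compound 4 (0.19 log units; within the scatter). Against the 4-carbamoyl-1H-1,2,3-triazol-1-yl group of compound 2, however, the exchange gives a 2.2-fold lower number from compound 2 to compound 4 (0.34 log units; beyond the scatter), the only step in this set to pass the scatter, so the position is not entirely silent, although the separation is modest and rests on this single pair. No measured information bears on what underlies this step.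

The compounds shown do not tell whether the step from compound 2 belongs to the sulfonylamino link or to the 4-chlorophenyl ring, a question that a plain phenylsulfonylamino or methylsulfonylamino group on the same carbon would address. On these data alone, how a primary amine, a carboxylic acid or a longer chain at this carbon would read also stays open, as does whether any change here matters while the rest of the shared core stays fixed.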